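The source may hold more compounds than are shown below. What is called first, only, known or untested is meant among the compounds shown, and "the series" means these compounds.

Compound 1 `Oc1cccc(-c2cc(-c3ccc(C(F)(F)F)cc3)cc(-c3ccccc3O)n2)c1` was examined in a functional assay on DU-145 cells (Homo sapiens) for inhibition; a lower number here means a stronger inhibitor, a higher number a weaker inhibitor. In this assay compound 1 gives only a limit, > 50000 nM. Compound 2 `Oc1ccc(-c2cc(-c3ccc(C(F)(F)F)cc3)cc(-c3ccccc3O)n2)cc1` carries 4-hydroxyphenyl in place of 3-hydroxyphenyl on an aromatic carbon; in this assay compound 2 likewise gives only a limit, > 50000 nM. The step that the two limits leave unreadable from compound 1 to compound 2 cannot be read, as the limit of > 50000 nM in this assay, at which 2 of the 2 values shown sit. Compound 3 `Oc1cccc(-c2cc(-c3ccc(OC(F)(F)F)cc3)cc(-c3ccccc3O)n2)c1` differs from compound 1 by trifluoromethoxy in place of trifluoromethyl on an aromatic carbon. No measured step bears on this change, and nothing shown points away from the limit. Compound 3 is therefore expected to give 50000 nM, within 15000 nM to 200000 nM. The expected step is a number no higher from compound 1 to compound 3 (the limit leaves the size open).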

Compound 3, half-maximal inhibitory concentration: 21100 nM
The estimate for compound 3 lay 2.4-fold (0.37 log units) above the measured number, and the stated range covers the measured number.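

Among the compounds shown, compound 3 alone gives a number in this assay rather than a limit: the limit of > 50000 nM in this assay, at which 2 of the 3 values shown sit. Trifluoromethoxy in place of trifluoromethyl, on an aromatic carbon para to a large group, gives an at least 2.3-fold lower number from compound 1 to compound 3 (0.37 log units; beyond the scatter), so a change at this position can bring a reading within the range of the assay. Going by these compounds, the true size of the step stays open, since compound 1 gives only a limit.

On these data alone, whether trifluoromethoxy would give a similar step alongside the 4-hydroxyphenyl of compound 2 remains open. So does how an amine or a carboxylic acid at this position would read.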